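This account rests on a few compounds, and the source may have more. Where it says the series, first, only, none or still open, it means among the compounds named here.

Measured so far:
compound 1, `CC[C@H](C1CC1)n1c(=O)c(C)nc2c(-c3cc(F)c(OC)cc3C)ccnc21`, 9.4 nM
compound 2, `CCCC(C1CC1)n1c(=O)c(C)nc2c(-c3ccc(Cl)cc3Cl)ccnc21`, 4.3 nM
compound 3, `COCC(C1CC1)n1c(=O)c(C)nc2c(-c3cc(F)c(OC)cc3Cl)ccnc21`, 1.5 nM

These three compounds share a core and were tested in a functional assay for antagonist activity at corticotropin-releasing factor receptor 1 (Rattus norvegicus); on this read-out higher numbers stand for weaker inhibition and lower numbers for stronger inhibition. Among them, compound 2 stands second highest; its nearest neighbour is compound 1, whose number lies higher by a margin beyond the usual scatter, and its furthest is compound 3, whose number lies lower, again beyond the scatter. The new member is compound 4, `CC[C@@H](C1CC1)n1c(=O)c(C)nc2c(-c3ccc(Cl)cc3Cl)ccnc21`, not yet measured. It differs from compound 2 in one place: 1-cyclopropylpropyl in place of 1-cyclopropylbutyl on an aromatic nitrogen, in words 1-cyclopropylpropyl in place of 1-cyclopropylbutyl on an aromatic nitrogen. Among the compounds with values here, no pair of measured compounds differs in exactly this way, so no step of this kind is known here. Shortening a chain by one carbon is a small change, and the expectation is a step within the scatter, with no clear direction. For compound 4 in this assay, the estimate is 4.5 nM, in the range 1.5 nM to 13 nM, which amounts to an expected step of a 1.0-fold higher number from compound 2 to compound 4 (0.02 log units; within the scatter).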

Compound 4, half-maximal inhibitory concentration: 7.4 nM
Compound 4: the middle estimate sits 1.6-fold (0.22 log units) below what was measured; the range from low to high includes it.
By their numbers in this assay, from the lowest: compound 3; then compounds 2, 4 and 1 (each within the scatter of the next, the first and the last beyond it).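

In this assay, within the data shown here, a 1.7-fold higher number from compound 2 to compound 4 (0.24 log units; within the scatter) gives the first direct comparison at this position, with the rest of the molecule unchanged. The step lies within the usual scatter, so these two compounds give no sign that 1-cyclopropylpropyl and 1-cyclopropylbutyl on the aromatic nitrogen differ at this receptor, although the entering group also brings a defined stereocentre. No measured information is available to explain this result.

The compounds shown leave open whether the opposite stereocentre in 1-cyclopropylpropyl would give a similar number, which would show whether the arrangement at this centre matters. They also leave open how far this position stays this accepting, for example with a longer chain such as 1-cyclopropylpentyl or with a chain ending in an amine.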